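Fluoro on the Aryl Ring of a Bis-triazole Thioether

The source may report more compounds than this note shows. Statements on the series, on what has been measured and on what is new or still open speak of the compounds shown alone.

Measured compounds in a functional assay on HT-29 cells (Homo sapiens) for inhibition, read by MTT assay, with a stated time of 48 h; a higher number here means a weaker inhibitor, a lower number a stronger inhibitor:
Compound 1 `Fc1ccc(-n2c(S)nnc2Sc2nnc(-c3ccccc3)n2-c2ccccc2)cc1` gives 32800 nM
Compound 2 `COc1ccc(-n2c(S)nnc2Sc2nnc(-c3ccccc3)n2-c2ccccc2)cc1` is reported as "not determined" (no result reported)
Compound 3 `Sc1nnc(CSc2nnc(-c3ccccc3)n2-c2ccccc2)n1-c1ccccc1` gives 5490 nM

Compound 3 stands lowest of the two numbers shown, and its nearest neighbour on the numbers is compound 1, which lies higher by a margin that is beyond the usual scatter of this assay. Compound 1 and compound 3 differ in more than one place, so nothing can be said about the cause of that gap; only the two values themselves are known. Compound 2 adds no number.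

Compound 4 `Fc1ccc(-n2c(S)nnc2CSc2nnc(-c3ccccc3)n2-c2ccccc2)cc1` is the next step from compound 3. The change is fluoro in place of hydrogen on an aromatic carbon; cut one bond further out it reads phenyl to 4-fluorophenyl, with the fluoro placed on an aromatic carbon of a six-membered aromatic ring of carbon only, para to a large group. Within the data shown here, no measured pair in this set isolates this single change, so there is no step to lean on.

With only one fluorine added and no ring, donor or acceptor change, the expectation in this assay is a step of no more than the scatter in either direction. Compound 4 is therefore estimated at 6000 nM, within 2500 nM to 15000 nM, meaning an expected step of a 1.1-fold higher number from compound 3 to compound 4 (0.04 log units; within the scatter).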

Compound 4, half-maximal inhibitory concentration: 16700 nM
Compound 4: middle estimate off by 2.8-fold (0.44 log units), on the low side; the measured number lies above the stated range.
By their numbers in this assay, from the lowest: compound 3; then compounds 4 and 1 (each within the scatter of the next).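

In this assay, among these compounds, phenyl to 4-fluorophenyl gives a 3.0-fold higher number from compound 3 to compound 4 (0.48 log units; beyond the scatter), the first step in this set that isolates a single change, and it shows that this ring position is not indifferent to replacing hydrogen with fluoro, even though only one heavy atom is added. Among the compounds shown here, compound 4 also gives a one-place comparison with compound 1 that the earlier compounds lacked: compound 4 gives 16700 nM and compound 1 gives 32800 nM, two values within the usual scatter of each other. Nothing in the data shown explains why the fluoro step has this direction or size.

On these data alone, this is a single pair, so it remains open whether the step belongs to fluoro specifically or would also appear with another group at the same place, such as chloro, methyl or an amine. Compound 2, which carries methoxy at that place, has no number to help, and it is also unknown whether fluoro at another position on the ring or on the other phenyl rings would give a similar step.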